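The compounds below may be only part of what the source reports. "The series", "measured", "known", "first", "only" and "open" are said of these compounds alone.

Of the compounds shown here, three that share one core have been tested in a functional assay on MCF7 cells (Homo sapiens) for antiproliferative activity, read by CCK-8 assay, with a stated time of 48 h; a lower number here means a stronger inhibitor, a higher number a weaker inhibitor. Compound 1 `Cc1[nH]c2ccccc2c1C1=C(Br)C(=O)C(c2c(C)[nH]c3ccccc23)=C(Br)C1=O` gives 7 ug/mL. Compound 2 `Cc1ccc(-c2[nH]c3ccccc3c2C2=C(Br)C(=O)C(c3c(C)[nH]c4ccccc34)=C(Br)C2=O)cc1` gives 3.25 ug/mL, and the step of a 2.2-fold higher number from compound 2 to compound 1 (0.33 log units; beyond the scatter) follows the change (methyl in place of 4-methylphenyl on an aromatic carbon). Compound 3 `COc1ccc2[nH]c(C)c(C3=C(Br)C(=O)C(c4c(-c5ccc(C)cc5)[nH]c5ccccc45)=C(Br)C3=O)c2c1` gives 2.56 ug/mL; the step of a 1.3-fold lower number from compound 2 to compound 3 (0.10 log units; within the scatter) is small, so compound 2 and compound 3 are not separated here.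

Compound 4 `COc1ccc2[nH]c(C)c(C3=C(Br)C(=O)C(c4c(C)[nH]c5ccccc45)=C(Br)C3=O)c2c1` has not yet been measured. It differs from compound 3 by methyl in place of 4-methylphenyl on an aromatic carbon, the same change that was made from compound 2 to compound 1, while the two cores differ by methoxy in place of hydrogen on an aromatic carbon. The expectation rests on the step of a 2.2-fold higher number from compound 2 to compound 1 (0.33 log units; beyond the scatter). Compound 4 is therefore expected to give about 5.6 ug/mL, likely between 3 ug/mL and 10.5 ug/mL. The expected step is a 2.2-fold higher number from compound 3 to compound 4 (0.34 log units; beyond the scatter), a weaker inhibitor than compound 3.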

Compound 4, half-maximal inhibitory concentration: > 25 ug/mL
Compound 4: a limit, no number (the forecaster's own chance of this, stated with the estimate: 3%); at least 4.4-fold (0.64 log units) between middle value and limit.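

In this assay, as far as these compounds go, compound 4 gives > 25 ug/mL, which is a limit of the assay and not a number, so the full size of any step to it stays unknown. Putting methyl in place of 4-methylphenyl gives an at least 9.7-fold higher number from compound 3 to compound 4 (0.98 log units; beyond the scatter), and this change does not carry over from one core to the other at the same size: the same change on two cores in this assay, a 2.2-fold higher number (0.33 log units; beyond the scatter) from compound 2 to compound 1 and an at least 9.7-fold higher number (0.98 log units; beyond the scatter) from compound 3 to compound 4, at least 4.5-fold (0.65 log units) apart, beyond the scatter of two such steps Methoxy in place of hydrogen gives an at least 3.5-fold higher number from compound 1 to compound 4 (0.55 log units; beyond the scatter), so it too depends on the core, though these four compounds do not show why the two changes fail to add up: the same change on two cores in this assay, a 1.3-fold lower number (0.10 log units; within the scatter) from compound 2 to compound 3 and an at least 3.5-fold higher number (0.55 log units; beyond the scatter) from compound 1 to compound 4, at least 4.5-fold (0.65 log units) apart, beyond the scatter of two such steps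

From the compounds shown here alone, whether the same holds for other groups at the place of the 4-methylphenyl, such as ethyl or a phenyl carrying an amine, remains open. So does the outcome with a hydroxyl or a fluorine in place of the methoxy.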